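This account rests on a few compounds, and the source may have more. Where it says the series, first, only, none or still open, it means among the compounds named here.

Measured compounds:
- compound 1 `OCc1cn2c(c1CO)CS[C@@H]2c1ccccc1`: "not determined" (no result reported)
- compound 2 `OCc1cn2c(c1CO)CS[C@@H]2c1cccnc1`: 30600 nM

The two measured compounds share one core and differ only in the aryl group that sits on the stereocentre of the sulfur-containing ring. In a functional assay on MCF7 cells (Homo sapiens) for cytotoxicity, read by MTT assay, with a stated time of 96 h (on this read-out higher numbers stand for weaker inhibition and lower numbers for stronger inhibition), compound 1 has no number of its own, so there is nothing to say about where it stands; it serves here only as the starting structure. In this assay compound 2 gives 30600 nM, a weak result by the standards of this read-out.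

Compound 3 `OCc1c(CO)c(-c2ccc(F)cc2)n2c1CS[C@@H]2c1ccccc1` is built from compound 1 by a single change: 4-fluorophenyl in place of hydrogen on an aromatic carbon. Among the measured compounds shown here, no pair of measured compounds shows what such a change does on this core, so there is no step to lean on, and the size and direction of the change in this assay remain open. Given that the only number available, that of compound 2, is weak, compound 3 is expected to land in a similarly weak region, at an estimated 20000 nM with a range from 4000 nM to 100000 nM.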

Compound 3, half-maximal inhibitory concentration: 26400 nM
Estimate against measurement, compound 3: 1.3-fold (0.12 log units) below; the range from low to high includes it.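

Among the compounds shown here, compound 1 has no number of its own in this assay, so the change from compound 1 to compound 3 gives no step that can be read. As far as these compounds go, what adding 4-fluorophenyl does on this core stays open. No evidence at hand bears on the result for compound 3.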